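The compounds below may be only part of what the source reports. "The series", "measured", "known", "first", "only" and "open" are said of these compounds alone.

Measured compounds in an assay on isolated protein for activation of cGMP-dependent protein kinase 1 (Homo sapiens), read by ADP-Glo, with stated times of 120 min and 40 min; a lower number here means that less compound is needed, a higher number that more compound is needed for the effect:
- compound 1, `Clc1cc(Cl)cc(CO[C@H]2CCCN(Cc3cccnc3)[C@H]2c2ccccc2)c1`: 112000 nM
- compound 2, `Clc1cc(Cl)cc(CO[C@H]2CCCN(Cc3ccccn3)[C@H]2c2ccccc2)c1`: its value is a limit of the assay, > 200000 nM
- compound 3, `O=C(O)c1ccc(CN2CCC[C@H](O[C@H](CO)c3cc(Cl)cc(Cl)c3)[C@@H]2c2ccccc2)cc1`: 11000 nM

Compound 1 stands highest of the two numbers in this assay; compound 3 gives the lower number, and the gap between compound 1 and compound 3 is beyond the scatter. Compound 2 gives only a limit of > 200000 nM in this assay, at which 1 of the 3 values shown sits, and no number.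

For the measured compounds named here, the only measured single-point step is an at least 1.7-fold higher number from compound 1 to compound 2 (0.25 log units; that floor lies within the scatter), a move of the ring nitrogen within the pyridyl that floors within the scatter. It does not concern the change now at hand.

Compound 4, `O=C(O)c1ccc(CN2CCC[C@H](OCc3cc(Cl)cc(Cl)c3)[C@@H]2c2ccccc2)cn1`, differs from compound 1 by carboxy in place of hydrogen on an aromatic carbon. Going by the values given here, no measured pair isolates this change. Compound 3 also carries a carboxy, but on a phenyl rather than a pyridyl, and it differs from compound 1 in a second place as well, so its lower number can only loosely point the direction. Taking that hint with caution, a modest move toward a lower number is expected, well short of the distance between compound 1 and compound 3.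

Compound 4 is expected to give 40000 nM in this assay, within 12000 nM to 150000 nM. The expected step is then a 2.8-fold lower number from compound 1 to compound 4 (0.45 log units; beyond the scatter).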

Compound 4, half-maximal effective concentration: > 200000 nM
Compound 4 was reported as a limit (the forecaster's own chance of this, stated with the estimate: 12%); at least 5.0-fold (0.69 log units) between middle value and limit.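

Carboxy in place of hydrogen, on an aromatic carbon next to the ring nitrogen and para to a large group, is the first change to the pyridin-3-yl of compound 1 that can be read on its own in this assay, and the step is an at least 1.7-fold higher number from compound 1 to compound 4 (0.25 log units; that floor lies within the scatter). The value of compound 4 is a limit of the assay, so the size of the step is not known, but the pair gives no sign that 6-carboxypyridin-3-yl lowers the number relative to pyridin-3-yl. Compound 2 and compound 4 both sit at a limit, and the step between them cannot be read: the limit of > 200000 nM in this assay, at which 2 of the 4 values shown sit.

On these data alone, whether a methyl ester or a primary amide in this same place on the pyridin-3-yl would give a readable number remains open, as does the effect of a carboxy at another carbon of that ring. For the compounds shown here, no single-change pair connects compound 3, at 11000 nM, to the other compounds, so the features behind its number also remain unresolved.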